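The source may hold more compounds than are shown below. What is called first, only, known or untested is meant among the compounds shown, and "the series" means these compounds.

Three compounds share one core and differ only in the aromatic group that sits on the amine nitrogen of the six-membered ring with two nitrogens. Compound 1 `COC(=O)C1=C(C)NC(=O)N(C(=O)NCCCN2CCN(c3ccccc3OC)CC2)C1c1ccc(F)c(F)c1` gives 18 nM in an assay on liver for binding affinity to Alpha-1B adrenergic receptor (Homo sapiens), using microsomes; a higher number here means a weaker inhibitor, a lower number a stronger inhibitor. Compound 2 `COC(=O)C1=C(C)NC(=O)N(C(=O)NCCCN2CCN(c3ccccc3O)CC2)C1c1ccc(F)c(F)c1` gives 16 nM in this assay, and compound 3 `CCOc1ccccc1N1CCN(CCCNC(=O)N2C(=O)NC(C)=C(C(=O)OC)C2c2ccc(F)c(F)c2)CC1` gives 8.8 nM. Compound 3 therefore has the lowest number of the three, yet the spread is small: a 1.1-fold lower number from compound 1 to compound 2 (0.05 log units; within the scatter), a 1.8-fold lower number from compound 2 to compound 3 (0.26 log units; within the scatter), and only a 2.0-fold lower number from compound 1 to compound 3 (0.31 log units; beyond the scatter).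

Compound 4 `COC(=O)C1=C(C)NC(=O)N(C(=O)NCCCN2CCN(c3cccc(Cl)c3)CC2)C1c1ccc(F)c(F)c1` takes the step (3-chlorophenyl in place of 2-ethoxyphenyl on an amine nitrogen in a ring). Within the data shown here, all three measured steps touched only what is attached to the oxygen on that aromatic ring, and all stayed small; none removed the oxygen or placed chlorine, so no measured step bears directly on this change. With the guidance from those steps being that this part of the molecule tolerates small edits, the expectation for compound 4 is a modest move toward a higher number, a 3.4-fold higher number from compound 3 to compound 4 (0.53 log units; beyond the scatter), with wide uncertainty. Compound 4 is estimated at 30 nM, between 8 nM and 120 nM.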

Compound 4, inhibition constant: 8.4 nM
Estimate against measurement, compound 4: 3.6-fold (0.55 log units) above; low and high end bracket the measured number.
By their numbers in this assay, from the lowest: compounds 4, 3, 2 and 1 (each within the scatter of the next, the first and the last beyond it).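

In this assay, the affinity seen with an oxygen-bearing group on the aromatic ring holds without any oxygen: swapping to 3-chlorophenyl, which has no hydrogen-bond acceptor, gives a 1.0-fold lower number from compound 3 to compound 4 (0.02 log units; within the scatter) and a 1.9-fold lower number from compound 2 to compound 4 (0.28 log units; within the scatter). Against the 2-methoxyphenyl group the same swap gives a 2.1-fold lower number from compound 1 to compound 4 (0.33 log units; beyond the scatter), so this position accepts a change of the whole group, not just small edits to what sits on the oxygen. No measurement at hand explains this result.

Each swap changes both the group on the aromatic ring and its place there, so a plain phenyl or a 2-chlorophenyl on the same amine nitrogen would be needed to separate those two changes. On these data alone, how a carboxylic acid or an amine on that aromatic ring would behave also remains open.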